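Swapping a Dichlorophenyl Ether for a Fluorophenyl Ether

A few compounds are considered here, and "the series" means these few. Any claim that something is new, unique, unknown or untested is made for them only; others in the source may bear on it.

Two measured compounds share one core and differ only in the aryl group on an ether oxygen. Compound 1 `C=CC(=O)NCc1coc(-c2c(N)ncnc2Nc2ccc(Oc3ccccc3)c(Cl)c2)n1` carries a plain phenyl there, and in an in vitro ADME assay on microsomes from liver (Rattus norvegicus) for metabolic stability, tested at 5 uM (on this read-out higher numbers stand for a longer-lived compound and lower numbers for a shorter-lived compound), compound 1 gives 0.983 h. Compound 2 `C=CC(=O)NCc1coc(-c2c(N)ncnc2Nc2ccc(Oc3cc(Cl)ccc3Cl)c(Cl)c2)n1` carries a 2,5-dichlorophenyl, and in this assay compound 2 gives 0.85 h. Among the measured compounds shown here, the only step between them, a 1.2-fold lower number from compound 1 to compound 2 (0.06 log units; within the scatter), is within the scatter, so compound 2 stands alongside compound 1 rather than apart from it; with only two numbers there is no wider spread to place it in.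

Compound 3 `C=CC(=O)NCc1coc(-c2c(N)ncnc2Nc2ccc(Oc3ccc(F)cc3)c(Cl)c2)n1` is a third variation: 4-fluorophenyl in place of 2,5-dichlorophenyl on an oxygen on an aromatic ring. For the measured compounds named here, the one comparison that bears on it is the exchange of phenyl for 2,5-dichlorophenyl on the same oxygen, which moved this assay by a 1.2-fold lower number from compound 1 to compound 2 (0.06 log units; within the scatter), a change within the scatter. Because a 1.2-fold lower number from compound 1 to compound 2 (0.06 log units; within the scatter) left the half-life essentially unchanged, a second swap at the same place is expected to do the same, giving an expected step of a 1.1-fold higher number from compound 2 to compound 3 (0.02 log units; within the scatter) in this assay. Compound 3 is therefore estimated at 0.9 h in this assay, with a range from 0.5 h to 1.7 h.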

Compound 3, half-life: 1.1 h
Estimate against measurement, compound 3: 1.2-fold (0.09 log units) below, within the range that was stated.
By their numbers in this assay, from the lowest: compounds 2, 1 and 3 (each within the scatter of the next).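

In this assay, going from 2,5-dichlorophenyl to 4-fluorophenyl on this oxygen exchanges two chlorine atoms for one fluorine and gives a 1.3-fold higher number from compound 2 to compound 3 (0.11 log units; within the scatter), so even a swap that alters both the halogen and its place on the ring does not separate the two compounds. The simplest change of the set, fluoro in place of hydrogen on an aromatic carbon, gives a 1.1-fold higher number from compound 1 to compound 3 (0.05 log units; within the scatter), which means that the plain phenyl and the 4-fluorophenyl also cannot be told apart, and all three aryl groups now read alike at this position. No measurement is at hand that would explain this flat result.

Going by these compounds, whether the picture holds for groups of a different kind on this oxygen, such as a pyridine ring or a phenyl carrying an amine or a carboxylic acid, stays open. Also open, on these data alone, is whether changes elsewhere on the shared core would move the number in this assay further than these swaps do.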